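Aryl exchange on the ring nitrogen of compound 3

The source may report more compounds than this note shows. Statements on the series, on what has been measured and on what is new or still open speak of the compounds shown alone.

Compound 3 `Cn1c(=O)c(C(=O)Nc2ccc(Oc3ccncc3-c3cccnc3)c(F)c2)nn(-c2ccccc2F)c1=O` is the weakest of the three measured compounds in a functional assay on MKN-45 cells (Homo sapiens) for cytotoxicity, read by MTT assay, with a stated time of 72 h (on this read-out higher numbers stand for weaker inhibition and lower numbers for stronger inhibition), giving 4780 nM. The other two share a different core: compound 1 `Fc1ccc(Nc2cc(Nc3ccc(Oc4ccncc4-c4cccnc4)c(F)c3)ncn2)cc1F` gives 80 nM, and compound 2 `COc1cc(Nc2cc(Nc3ccc(Oc4ccncc4-c4cccnc4)c(F)c3)ncn2)cc(OC)c1` gives 1750 nM. Compound 3 thus stands a clear margin beyond both, its nearest neighbour being compound 2.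

Compound 4 `Cn1c(=O)c(C(=O)Nc2ccc(Oc3ccncc3-c3cccnc3)c(F)c2)nn(-c2ccc(F)c(Cl)c2)c1=O` differs from compound 3 in one place: 3-chloro-4-fluorophenyl in place of 2-fluorophenyl on an aromatic nitrogen. Going by the values given here, the only measured step, a 22-fold higher number from compound 1 to compound 2 (1.34 log units; beyond the scatter), concerns an aryl group on a different kind of nitrogen and on a different core, so it bears on the present change only loosely; it does show that the identity of the terminal aryl can move this read-out by a large amount. The aryl entering compound 4 carries halogens, as does the aryl of compound 1, whereas the aryl leaving compound 3 is also a halogenated phenyl, so the expected step in this assay is small, leaning towards a lower number, and may not exceed the scatter. Compound 4 is accordingly estimated at 3000 nM, with a range from 1000 nM to 9000 nM, which means an expected step of a 1.6-fold lower number from compound 3 to compound 4 (0.20 log units; within the scatter).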

Compound 4, half-maximal inhibitory concentration: 10100 nM
Beside the measured number, compound 4's estimate is 3.4-fold (0.53 log units) below it; the measured number lies above the stated range.
By their numbers in this assay, from the lowest: compound 1; then compound 2; then compound 3; then compound 4.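

Working notes on the aryl group on the aromatic nitrogen: in this assay, 3-chloro-4-fluorophenyl in place of 2-fluorophenyl gives a 2.1-fold higher number from compound 3 to compound 4 (0.32 log units; beyond the scatter), so this position on the core of compound 3 does respond to the choice of halogenated phenyl, and this exchange moves it towards weaker inhibition. Keeping a halogenated aryl here is therefore no guarantee of an unchanged read-out, and the added chlorine with the shifted fluorine does not bring a lower number on this core, although the two aryl groups differ in both halogen count and halogen placement, so this single pair cannot separate those two changes. Nothing measured on these compounds accounts for the direction or size of the step.

Open, from the compounds shown here alone, is how a plain phenyl group would compare at this position, which would show whether the halogens matter at all here. Also open, going by these compounds, is whether a benzyl group or a chain ending in an amine on the same nitrogen would be tolerated, or would shift the number further in either direction.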